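Triazole-bearing butenolides against HeLa proliferation: working notes

This account rests on a few compounds, and the source may have more. Where it says the series, first, only, none or still open, it means among the compounds named here.

Measured so far:
compound 1, `Cc1ccc(-c2cn(C/C=C3\OC(=O)C(OCc4ccccc4)=C3OCc3ccccc3)nn2)cc1`, 7480 nM in a functional assay on HeLa cells (Homo sapiens) for antiproliferative activity, read by MTT assay, with a stated time of 72 h; a lower number here means a stronger inhibitor, a higher number a weaker inhibitor
compound 2, `CCCCCc1ccc(-c2cn(C/C=C3\OC(=O)C(OCc4ccccc4)=C3OCc3ccccc3)nn2)cc1`, > 100000 nM
compound 3, `O=C1O[C@H]([C@@H](O)Cn2cc(CNS(=O)(=O)c3ccc(F)cc3)nn2)C(OCc2ccccc2)=C1OCc1ccccc1`, 25000 nM

The value recorded for compound 2 is a limit of this assay and not a number (the limit of > 100000 nM in this assay, at which 1 of the 3 values shown sits). Among the two numbers, compound 3 gives the highest, with compound 1 lower and beyond the scatter. Going by the values given here, the single measured step, an at least 13-fold higher number from compound 1 to compound 2 (1.12 log units; beyond the scatter), is large and runs to the limit; it concerns the substituent on the aromatic ring attached to the five-membered ring with three nitrogens.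

Compound 4, `COc1ccc(-c2cn(C[C@H](O)[C@H]3OC(=O)C(OCc4ccccc4)=C3OCc3ccccc3)nn2)cc1`, differs from compound 3 by 4-methoxyphenyl in place of (((4-fluorophenyl)sulfonyl)amino)methyl on an aromatic carbon. Among the compounds with values here, no measured step covers this exchange, and no pair of measured compounds differs at this place alone. Within the data shown here, the only guide is that compound 1, which carries a small para-substituted phenyl on the same five-membered ring, gives 7480 nM in this assay, whereas compound 3 with its sulfonamide-bearing chain gives 25000 nM. Compound 4 is therefore expected to give 9000 nM in this assay, within 2500 nM to 40000 nM, an expected step of a 2.8-fold lower number from compound 3 to compound 4 (0.44 log units; beyond the scatter) toward a lower number, with the direction held loosely and no weight put on its size.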

Compound 4, half-maximal inhibitory concentration: 16400 nM
Compound 4: middle estimate off by 1.8-fold (0.26 log units), on the low side, within the range that was stated.
By their numbers in this assay, from the lowest: compound 1; then compounds 4 and 3 (each within the scatter of the next). At a limit, above all of these: compound 2.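

In this assay, exchanging (((4-fluorophenyl)sulfonyl)amino)methyl for 4-methoxyphenyl on an aromatic carbon of the five-membered aromatic ring with 3 nitrogen gives a 1.5-fold lower number from compound 3 to compound 4 (0.18 log units; within the scatter), so this position now has a first measured step, and that step does not separate the two groups. The group that leaves has 12 heavy atoms, 1 hydrogen-bond donor and 2 hydrogen-bond acceptors, the group that enters has 8 heavy atoms, 0 hydrogen-bond donors and 1 hydrogen-bond acceptor, and both carry one six-membered aromatic ring of carbon only, so in this pair the read-out tolerates a marked change in the attached group. No measured property on hand accounts for this step.

From the compounds shown here alone, whether the large change seen in an at least 13-fold higher number from compound 1 to compound 2 (1.12 log units; beyond the scatter), which concerns the substituent on the phenyl ring, would recur on the core of compound 4 remains open. Also open, going by these compounds, is how this position responds to a group of another kind, such as an amine, a carboxylic acid or a longer alkoxy chain in place of the methoxy group of compound 4.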